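Replacing 2-Bromophenyl With Pyridin-3-yl: An Expected Outcome

The source may report more compounds than this note shows. Statements on the series, on what has been measured and on what is new or still open speak of the compounds shown alone.

Two measured compounds share one core and differ only in the ring attached to a saturated ring carbon. Compound 1 `CC(=O)N1N=C(c2ccc3ccccc3c2)OC1c1ccccc1Br` carries 2-bromophenyl there, and compound 2 `CC(=O)N1N=C(c2ccc3ccccc3c2)OC1c1ccc(Cl)cc1` carries 4-chlorophenyl. In a functional assay on HepG2 cells (Homo sapiens) for antiproliferative activity, read by MTT assay, with a stated time of 48 h (a lower number here means a stronger inhibitor, a higher number a weaker inhibitor), compound 1 gives 3.98 ug/mL, the higher of the two numbers, and compound 2 gives 1.88 ug/mL. Among the compounds with values here, the one measured step, a 2.1-fold lower number from compound 1 to compound 2 (0.33 log units; beyond the scatter), shows that exchanging the ring on that saturated ring carbon can move the number modestly. Compound 3 `CC(=O)N1N=C(c2ccc3ccccc3c2)OC1c1cccnc1` is the unmeasured member; it differs from compound 1 by pyridin-3-yl in place of 2-bromophenyl on a saturated ring carbon. Within the data shown here, no measured pair exchanges a phenyl ring for pyridin-3-yl, so the single step between compound 1 and compound 2 is the only guide, and it points to a change of modest size at most. The expected step is a 1.3-fold lower number from compound 1 to compound 3 (0.12 log units; within the scatter), small and uncertain in direction. Compound 3 is therefore estimated at 3 ug/mL in this assay, with a range from 1.2 ug/mL to 7.5 ug/mL.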

Compound 3, half-maximal inhibitory concentration: 2.86 ug/mL
Beside the measured number, compound 3's estimate is 1.0-fold (0.02 log units) above it; measured number inside the range.
By their numbers in this assay, from the lowest: compounds 2, 3 and 1 (each within the scatter of the next, the first and the last beyond it).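

In this assay, the saturated ring carbon accepts a ring of a different kind: pyridin-3-yl, with a ring nitrogen and a hydrogen-bond acceptor that 2-bromophenyl lacks, gives a 1.4-fold lower number from compound 1 to compound 3 (0.14 log units; within the scatter) and also a 1.5-fold higher number from compound 2 to compound 3 (0.18 log units; within the scatter) when set against 4-chlorophenyl. Compound 3 therefore cannot be told apart from either compound bearing a halogen, even though those two are separated by a 2.1-fold lower number from compound 1 to compound 2 (0.33 log units; beyond the scatter) and lie beyond the scatter of each other. Nothing available explains these numbers.

The compounds shown leave open whether the placing of the ring nitrogen matters, as pyridin-2-yl or pyridin-4-yl at this carbon would show. They also leave open how an aminophenyl ring, a carboxylic acid on the ring, or a longer chain in place of the ring would read.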